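A Methoxy Group Added to the Anilino Ring

A few compounds are considered here, and "the series" means these few. Any claim that something is new, unique, unknown or untested is made for them only; others in the source may bear on it.

Going by the values given here, compound 1 `Cc1nc(SCC(=O)Nc2nc(-c3ccc(Cl)cc3)cs2)n(Nc2ccccc2)c1C` is the only compound here with a plain number: in a functional assay on SF-268 cells (Homo sapiens) for antiproliferative activity, read by sulforhodamine B assay, with a stated time of 48 h (a higher number here means a weaker inhibitor of growth, a lower number a stronger inhibitor of growth), compound 1 gives 20100 nM. Compound 2 `Cc1ccc(Nn2c(SCC(=O)Nc3nc(-c4ccccc4)cs3)nc(C)c2C)cc1` reaches only a limit of this assay, recorded as > 100000 nM. Compound 3 `COc1ccc(Nn2c(SCC(=O)Nc3nc(-c4ccc(Cl)cc4)cs3)nc(C)c2C)cc1` differs from compound 1 by methoxy in place of hydrogen on an aromatic carbon. Among the compounds with values here, no measured pair isolates this single change, so its size is open. The step from compound 1 to compound 3 is expected to be small, within the scatter or leaning slightly toward weaker inhibition: a 1.5-fold higher number from compound 1 to compound 3 (0.17 log units; within the scatter). Compound 3 is therefore estimated at 30000 nM, in a range from 10000 nM to 100000 nM.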

Compound 3, concentration for total growth inhibition: > 100000 nM
Compound 3 gave a limit, no number (the forecaster's own chance of this, stated with the estimate: 25%); at least 3.3-fold (0.52 log units) between middle value and limit.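

In this assay, going from anilino to (4-methoxyphenyl)amino is not a neutral change at this position: the result is an at least 4.9-fold higher number from compound 1 to compound 3 (0.69 log units; beyond the scatter). Growth inhibition on this ring therefore depends on what sits on this aromatic carbon. The step gives only a lower bound, and its true size stays unknown: the limit of > 100000 nM in this assay, at which 2 of the 3 values shown sit.

Going by these compounds, whether a fluorine atom, a hydroxyl or an amine on this same carbon would keep a measurable value stays open. Compound 2 also reaches a limit, but it differs from compound 1 in more than one place, so it cannot separate the effect of any single change.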